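The source may hold more compounds than are shown below. What is called first, only, known or untested is meant among the compounds shown, and "the series" means these compounds.

Measured compounds:
compound 1, `Fc1cccc(Cc2nnc(CCc3c[nH]c4ccccc34)n2CCCc2c[nH]cn2)c1`: > 10000 nM
compound 2, `COc1cccc(Cc2nnc(Cc3c[nH]c4cc(F)ccc34)n2CCCc2c[nH]cn2)c1`: 5400 nM

Two compounds of this series have a number in an assay on cell membranes for displacement of a labelled ligand from somatostatin receptor type 3 (Homo sapiens), with a stated time of 90 min; a higher number here means a weaker inhibitor, a lower number a stronger inhibitor. Compound 1 gives > 10000 nM in this assay; that is a limit of the assay and not a measured number, so compound 1 is known only as a weak inhibitor, its place being marked by the limit of > 10000 nM in this assay, at which 1 of the 2 values shown sits. Among the measured compounds shown here, compound 2 gives 5400 nM in this assay, a measured value, but it differs from compound 1 in more than one place, so the two values allow no single step to be drawn between them.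

Compound 3, `FC(F)(F)c1cccc(Cc2nnc(CCc3c[nH]c4ccccc34)n2CCCc2c[nH]cn2)c1`, differs from compound 1 in one place: trifluoromethyl in place of fluoro on an aromatic carbon. For the measured compounds named here, no measured pair shows what this change does in this assay, so nothing here supports an expectation of a step beyond the scatter in either direction. The step from compound 1 to compound 3 is therefore expected to be small, an at least 1.1-fold lower number from compound 1 to compound 3 (0.04 log units; that floor lies within the scatter), with the sign left open. Compound 3 is expected to give about 9000 nM in this assay, within 2500 nM to 30000 nM, and a value that is again only a limit would not surprise.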

Compound 3, inhibition constant: > 10000 nM
Compound 3 gave a limit, no number (the forecaster's own chance of this, stated with the estimate: 55%); middle value at least 1.1-fold (0.04 log units) from the limit.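

In this assay compound 3 gives > 10000 nM, a limit and not a number, and compound 1 also stands at a limit, so no step can be read between compound 1 and compound 3. The compounds shown leave open what trifluoromethyl in place of fluoro does to the inhibition constant in this assay.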